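Extending the methyl of compound 1 with piperidin-4-yl

The source may hold more compounds than are shown below. What is called first, only, known or untested is meant among the compounds shown, and "the series" means these compounds.

Compound 1 `Cc1cc2[nH]nc(N)c2c(=O)[nH]1` stands highest of the three numbers in an assay on isolated protein for inhibition of protein kinase C zeta type (Homo sapiens), read by mobility shift assay, tested at 30 uM (a lower number here means less inhibition, a higher number more inhibition at the concentration tested (going by the name of the read-out)), where compound 1 gives 10%. Compound 2 `Nc1n[nH]c2cc(-c3cccs3)[nH]c(=O)c12` gives -27% in this assay, and compound 3 `CC(C)(C)c1cc2[nH]nc(N)c2c(=O)[nH]1` gives -9%. Both measured departures from compound 1 lower the number: a number 37 percentage points lower from compound 1 to compound 2 (beyond the scatter) and a number 19 percentage points lower from compound 1 to compound 3 (beyond the scatter), while between the two variants a number 18 percentage points higher from compound 2 to compound 3 (beyond the scatter). Compound 4 `Nc1n[nH]c2cc(CC3CCNCC3)[nH]c(=O)c12` differs from compound 1 in one place: piperidin-4-yl in place of hydrogen on a saturated chain carbon bound to an aromatic carbon. The measured steps bear on this only indirectly, since both of them exchange the methyl itself, whereas in compound 4 the methyl carbon is kept and carries the new group. Among the compounds with values here, the two known changes at this aromatic carbon went downward by a large and a modest amount, so a further change at the same site is expected to give, at most, a modest lowering or none beyond the scatter; no measured step supports a rise. The estimated step is a number 10 percentage points lower from compound 1 to compound 4 (within the scatter). Compound 4 is therefore expected to give about 0% in this assay, within a range from -25% to 20%.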

Compound 4, a percentage reported as inhibition, at one concentration (the size of the read-out at that concentration, not a potency): -56%
Beside the measured number, compound 4's estimate is 56 percentage points above it; the measured number lies below the stated range.
By their numbers in this assay, from the lowest: compound 4; then compound 2; then compound 3; then compound 1.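

In this assay, keeping the methyl carbon and placing piperidin-4-yl on it does not preserve the number of compound 1: the change gives a number 66 percentage points lower from compound 1 to compound 4 (beyond the scatter) and is no gentler than replacing the methyl outright, as in a number 37 percentage points lower from compound 1 to compound 2 (beyond the scatter) at the same aromatic carbon. With compound 4 at -56% as the lowest number of the series, all three changes made around this carbon now lower the number, and none of the compounds shown goes against that, so building outward from the methyl carbon offers no route upward so far. Nothing at hand bears on why this step falls so far.

Going by these compounds, whether the fall goes with the ring, with its nitrogen or simply with the added length remains open, and cyclohexyl on the same carbon, an acetyl group on the piperidine nitrogen, or a short chain such as ethyl or aminomethyl in place of the methyl would begin to separate these. Also open, on these data alone, is what the numbers below zero mean for this series, since each is a reading at one concentration and gives no potency.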